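Quinolin-2-yl for 1-methyl-1H-benzimidazol-2-yl: an expected clearance

The source may hold more compounds than are shown below. What is called first, only, known or untested is meant among the compounds shown, and "the series" means these compounds.

Compound 1 `O=C(Nc1ccccc1Cl)N1CCC(c2nc(-c3ccc4ccccc4n3)no2)CC1`: > 200 mL.min-1.g-1 (a limit)
Compound 2 `O=C(NC1CCS(=O)(=O)CC1)N1CCC(c2nc(-c3ccc4ccccc4n3)no2)CC1`: 8 mL.min-1.g-1
Compound 3 `Cn1c(-c2noc(C3CCN(C(=O)NC4CCCCC4)CC3)n2)nc2ccccc21`: 192 mL.min-1.g-1

All three were measured in an in vitro ADME assay on microsomes from liver (Rattus norvegicus) for metabolic stability; a lower number here means slower removal, a higher number faster removal of the compound. The entry for compound 1 is a limit of the assay, not a number. Compound 3 stands high at 192 mL.min-1.g-1, far above compound 2 at 8 mL.min-1.g-1.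

Compound 4 `O=C(NC1CCCCC1)N1CCC(c2nc(-c3ccc4ccccc4n3)no2)CC1` differs from compound 3 in one place: quinolin-2-yl in place of 1-methyl-1H-benzimidazol-2-yl on an aromatic carbon. Among the compounds with values here, the only measured step, an at least 25-fold lower number from compound 1 to compound 2 (1.39 log units; beyond the scatter), is large, but it lies on an amide-type nitrogen, not at this place. It therefore gives no size for this change, and no step beyond the scatter is expected in this assay. The expected step is a 1.4-fold lower number from compound 3 to compound 4 (0.14 log units; within the scatter). Compound 4 is expected at 140 mL.min-1.g-1, with an estimated range from 60 mL.min-1.g-1 to 280 mL.min-1.g-1.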

Compound 4, intrinsic clearance in microsomes: > 300 mL.min-1.g-1
Compound 4: no number, only a limit (the forecaster's own chance of this, stated with the estimate: 35%); at least 2.1-fold (0.33 log units) between middle value and limit.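

With cyclohexyl on the amide-type nitrogen, quinolin-2-yl on this aromatic carbon brings no slower removal than 1-methyl-1H-benzimidazol-2-yl in this assay, with an at least 1.5-fold higher number from compound 3 to compound 4 (0.19 log units; that floor lies within the scatter). With quinolin-2-yl kept, the group on the amide-type nitrogen makes the large difference, cyclohexyl replacing 1,1-dioxothian-4-yl: an at least 37-fold higher number from compound 2 to compound 4 (1.57 log units; beyond the scatter). The step between compound 1 and compound 4 cannot be read, since both entries are limits.

Going by these compounds, the entry for compound 4 is a limit, so the true size of the ring change stays open: the limit of > 300 mL.min-1.g-1 in this assay, at which 1 of the 4 values shown sits. Also open is whether a hydroxyl group or an amine on the cyclohexyl would lower the number.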